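The compounds below may be only part of what the source reports. "The series", "measured", "known", "first", "only" and "open" are said of these compounds alone.

Three members of the series have numbers in a functional assay on MGC-803 cells (Homo sapiens) for cytotoxicity, read by MTT assay, with a stated time of 72 h; a higher number here means a weaker inhibitor, a lower number a stronger inhibitor. Compound 1 `FC(F)(F)c1ccc(CSc2nc(Nc3cccc(C(F)(F)F)c3)c3ccccc3n2)cc1` gives 15100 nM. Compound 3 `FC(F)(F)c1ccc(CSc2nc(Nc3ccc(Cl)cc3)c3ccccc3n2)cc1` gives 16800 nM. Compound 2 `O=[N+]([O-])c1cccc(Nc2nc(SCc3ccc(C(F)(F)F)cc3)nc3ccccc23)c1` sits at a limit of the measurement, (the limit of > 50000 nM in this assay, at which 1 of the 3 values shown sits), and gives > 50000 nM. Exchanging the ring substituent, an at least 3.3-fold higher number from compound 1 to compound 2 (0.51 log units; beyond the scatter), whereas swapping the whole aryl group on the amine nitrogen, a 1.1-fold higher number from compound 1 to compound 3 (0.05 log units; within the scatter). For the remaining pair, an at least 2.9-fold lower number from compound 2 to compound 3 (0.47 log units; beyond the scatter). Of the two numbers, compound 3 holds the higher one, with compound 1 close enough to sit within the scatter; the third value is only a limit.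

Compound 4 `COc1ccc(Nc2nc(SCc3ccc(C(F)(F)F)cc3)nc3ccccc23)cc1` differs from compound 3 by methoxy in place of chloro on an aromatic carbon. For the measured compounds named here, no measured step alters this group. As far as these compounds go, the nearest comparisons are the aryl swaps, where a 1.1-fold higher number from compound 1 to compound 3 (0.05 log units; within the scatter) and an at least 2.9-fold lower number from compound 2 to compound 3 (0.47 log units; beyond the scatter), so both a flat outcome and a modest shift in either direction remain open in this assay. Going by the values given here, with no direct precedent, the expectation for compound 4 is a number close to that of compound 3, a 1.1-fold lower number from compound 3 to compound 4 (0.02 log units; within the scatter), with an estimate of 16000 nM and a range from 7000 nM to 40000 nM.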

Compound 4, half-maximal inhibitory concentration: 13800 nM
Beside the measured number, compound 4's estimate is 1.2-fold (0.06 log units) above it, within the range that was stated.
By their numbers in this assay, from the lowest: compounds 4, 1 and 3 (each within the scatter of the next). At a limit, above all of these: compound 2.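

In this assay, for the compounds shown here, methoxy in place of chloro on this aromatic carbon, para to a large group, is the first direct change at this position, and it stays within the scatter: a 1.2-fold lower number from compound 3 to compound 4 (0.09 log units; within the scatter). The 4-methoxyphenyl group also matches the 3-(trifluoromethyl)phenyl group within the scatter, a 1.1-fold lower number from compound 1 to compound 4 (0.04 log units; within the scatter), so only the 3-nitrophenyl group stands apart, an at least 3.6-fold lower number from compound 2 to compound 4 (0.55 log units; beyond the scatter). That last step rests on a limit and not on a number for compound 2: the limit of > 50000 nM in this assay, at which 1 of the 4 values shown sits.

As far as these compounds go, whether an amine or a carboxylic acid on this carbon would move the number beyond the scatter remains open. Also open, from the compounds shown here alone, is whether the gap seen with compound 2 belongs to the nitro group itself or to where it sits on the ring.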